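The source may report more compounds than this note shows. Statements on the series, on what has been measured and on what is new or still open speak of the compounds shown alone.

Measured compounds in a functional assay on PC-3 cells (Homo sapiens) for cytotoxicity, read by MTT assay, with a stated time of 72 h; on this read-out lower numbers stand for stronger inhibition and higher numbers for weaker inhibition:
compound 1 `Cc1ccccc1Nc1nc(SCc2ccc(C(F)(F)F)cc2)nc2ccccc12` gives 36900 nM
compound 2 `O=[N+]([O-])c1ccc(Nc2nc(SCc3ccc(C(F)(F)F)cc3)nc3ccccc23)cc1` gives 7900 nM
compound 3 `FC(F)(F)c1ccc(CSc2nc(Nc3ccc(C(F)(F)F)cc3)c3ccccc3n2)cc1` gives 7880 nM

Compound 1 has the highest number of the three and is therefore the weakest inhibitor shown. Compound 4 `COc1cc(Nc2nc(SCc3ccc(C(F)(F)F)cc3)nc3ccccc23)cc(OC)c1` has not been measured; it differs from compound 1 in one place: 3,5-dimethoxyphenyl in place of 2-methylphenyl on a nitrogen on an aromatic ring. Two measured steps alter the same ring: a 4.7-fold lower number from compound 1 to compound 2 (0.67 log units; beyond the scatter) and a 4.7-fold lower number from compound 1 to compound 3 (0.67 log units; beyond the scatter). Each replaced 2-methylphenyl with a phenyl bearing a single nitro or trifluoromethyl group and each gave a modest improvement beyond the scatter, while between those two products a 1.0-fold lower number from compound 2 to compound 3 (0.00 log units; within the scatter). Compound 4 instead carries two methoxy groups, so neither step matches it closely. The expected step is a 2.5-fold lower number from compound 1 to compound 4 (0.39 log units; beyond the scatter), a smaller improvement than either. Compound 4 is estimated at 15000 nM, within 5000 nM to 45000 nM.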

Compound 4, half-maximal inhibitory concentration: > 50000 nM
Compound 4 gave a limit, no number; the forecaster's own chance of this, stated with the estimate: 5%; middle value at least 3.3-fold (0.52 log units) from the limit.
By their numbers in this assay, from the lowest: compounds 3 and 2 (each within the scatter of the next); then compound 1. At a limit, above all of these: compound 4.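

In this assay compound 4 gives > 50000 nM, which is a limit and not a number. Changing the ring on this nitrogen can therefore also push the number up, not only down: the data show an at least 6.3-fold higher number from compound 2 to compound 4 (0.80 log units; beyond the scatter) and an at least 6.3-fold higher number from compound 3 to compound 4 (0.80 log units; beyond the scatter). The remaining step is an at least 1.3-fold higher number from compound 1 to compound 4 (0.13 log units; that floor lies within the scatter), so 3,5-dimethoxyphenyl cannot be ranked against 2-methylphenyl.

Still open, on these data alone, is how an unsubstituted phenyl, or a phenyl carrying one methoxy group, would read on this nitrogen. The same goes for a phenyl bearing an amine or a carboxylic acid.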